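The source may hold more compounds than are shown below. What is called first, only, known or untested is meant among the compounds shown, and "the series" means these compounds.

Compound 3 `Nc1sc(-c2ccc(Cl)cc2)c(-c2ccc(Cl)cc2)c1C(=O)NC1CCCC1` gives the lowest number of the three measured in a functional assay on A549 cells (Homo sapiens) for inhibition, read by sulforhodamine B assay, with a stated time of 72 h (a higher number here means a weaker inhibitor, a lower number a stronger inhibitor), at 6790 nM. Compound 2 `Nc1sc(-c2ccc(Cl)cc2)c(-c2ccc(Cl)cc2)c1C(=O)NCc1ccccc1` gives 16300 nM, and compound 1 `CCOC(=O)Nc1sc(-c2ccc(Cl)cc2)c(-c2ccc(Cl)cc2)c1C(=O)NC1CC1` gives 39800 nM. Going by the values given here, the one step between compounds differing in a single place is a 2.4-fold lower number from compound 2 to compound 3 (0.38 log units; beyond the scatter).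

Compound 4 `Nc1sc(-c2ccc(Cl)cc2)c(-c2ccc(Cl)cc2)c1C(=O)NC1CCC1` differs from compound 3 by cyclobutyl in place of cyclopentyl on an amide-type nitrogen. Among the compounds with values here, only a 2.4-fold lower number from compound 2 to compound 3 (0.38 log units; beyond the scatter) bears on this site, and it swaps benzyl for a carbocycle rather than changing ring size; no measured pair shows a change in ring size alone. Within the data shown here, with that as the sole guide, the move from cyclopentyl to cyclobutyl is expected to shift the number little, likely within the scatter, so the estimated step is a 1.2-fold higher number from compound 3 to compound 4 (0.07 log units; within the scatter). Compound 4 is therefore expected to give about 8000 nM, within a range from 4000 nM to 16000 nM.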

Compound 4, half-maximal inhibitory concentration: 12500 nM
Compound 4: middle estimate off by 1.6-fold (0.19 log units), on the low side; measured number inside the range.
By their numbers in this assay, from the lowest: compounds 3, 4 and 2 (each within the scatter of the next, the first and the last beyond it); then compound 1.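

Changing ring size alone at this amide-type nitrogen gives a 1.8-fold higher number from compound 3 to compound 4 (0.27 log units; within the scatter) in this assay, so cyclobutyl and cyclopentyl cannot be told apart here. Cyclobutyl against benzyl gives a 1.3-fold lower number from compound 2 to compound 4 (0.12 log units; within the scatter), which also stays within the scatter, so compound 4 cannot be separated from either neighbour, although compound 2 and compound 3 do differ beyond it. Nothing available explains these results. The compounds shown leave open how a cyclohexyl group or an open butyl chain on this nitrogen would read, and whether any ring size there separates beyond the scatter.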